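Oxan-4-yl on the terminal amine of compound 3

This account rests on a few compounds, and the source may have more. Where it says the series, first, only, none or still open, it means among the compounds named here.

Compound 1, `c1ccc(CNCCCCN(C[C@H]2Cc3ccccc3CN2)[C@H]2CCCc3cccnc32)cc1`. In a functional assay on cells for agonist activity at C-X-C chemokine receptor type 4 (Homo sapiens), read by fluorescence and calcium flux, with a stated time of 90 s (a higher number here means that more compound is needed for the effect, a lower number that less compound is needed), compound 1 gives > 30000 nM, which is a limit of the assay and not a number.
Compound 2, `c1ccc2c(c1)CN[C@@H](CN(CCCCNCC1CCSCC1)[C@H]1CCCc3cccnc31)C2`. In this assay compound 2 gives > 30000 nM, again a limit.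
Compound 3, `CC(C)(CN)CCN(C[C@H]1Cc2ccccc2CN1)[C@H]1CCCc2cccnc21`. In this assay compound 3 gives > 30000 nM, also a limit.

Compound 3 therefore stands at the limit of > 30000 nM in this assay, at which 3 of the 3 values shown sit; no value among the three measured compounds is a number. Compound 4, `CC(C)(CCN(C[C@H]1Cc2ccccc2CN1)[C@H]1CCCc2cccnc21)CNC1CCOCC1`, is compound 3 with oxan-4-yl in place of hydrogen on an amine nitrogen.

The measured steps that touch compound 3 are a step that the two limits leave unreadable from compound 1 to compound 3 and a step that the two limits leave unreadable from compound 2 to compound 3, and the remaining step is a step that the two limits leave unreadable from compound 1 to compound 2. None of them yields a readable size, so nothing measured here tells how adding oxan-4-yl on the amine nitrogen should move this assay in either direction, nor whether it moves it at all beyond the scatter.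

With every reference point sitting at the limit, compound 4 is expected most probably to return a limit as well, and its estimate is placed at 30000 nM, within 5000 nM to 150000 nM. The step this estimate implies, a number no higher from compound 3 to compound 4 (the limit leaves the size open), is an expectation only, not a reading of the data.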

Compound 4, half-maximal effective concentration: > 30000 nM
Compound 4 gave a limit, no number; the forecaster's own chance of this, stated with the estimate: 70%; the middle value lies on the limit itself.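

In this assay compound 4 gives > 30000 nM, a limit and not a number, so the steps reaching compound 4 from compound 1, compound 2 and compound 3 cannot be read. Whether any of these changes alters agonist activity stays open, as every compound shown rests on one limit: the limit of > 30000 nM in this assay, at which 4 of the 4 values shown sit.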